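The source may hold more compounds than are shown below. What is called first, only, known or untested is meant among the compounds shown, and "the series" means these compounds.

Measured compounds in an assay on T-REx-293 cells for inhibition of potassium channel subfamily T member 1 (Mus musculus), read by patch clamp; a higher number here means a weaker inhibitor, a lower number a stronger inhibitor:
compound 1 `Cc1cc(-c2noc([C@H](C)NC(=O)c3cc(C(F)(F)F)nn3C)n2)ccn1` — 14500 nM
compound 2 `COc1cc(-c2noc([C@H](C)NC(=O)c3cc(C(F)(F)F)nn3C)n2)ccn1` — 3000 nM

Compound 2 holds the lowest of the two numbers in this assay. For the measured compounds named here, its only neighbour is compound 1, and the step of a 4.8-fold lower number from compound 1 to compound 2 (0.68 log units; beyond the scatter) separates them beyond the scatter, so compound 2 is the stronger inhibitor of the pair.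

Compound 3 `C[C@H](NC(=O)c1cc(C(F)(F)F)nn1C)c1nc(-c2ccnc(C3CC3)c2)no1` has not yet been measured. It differs from compound 2 in one place: cyclopropyl in place of methoxy on an aromatic carbon. Going by the values given here, no measured step shows a cyclopropyl entering anywhere, so the only step that bears on this change is the one from compound 1 to compound 2, in which methoxy replaced methyl on the same aromatic carbon and the number fell modestly, as a 4.8-fold lower number from compound 1 to compound 2 (0.68 log units; beyond the scatter) records. Cyclopropyl carries no hydrogen-bond acceptor, which methoxy does, and in that respect compound 3 resembles compound 1 more than compound 2. He therefore expects the number for compound 3 to move upward, by an estimated 2.2-fold higher number from compound 2 to compound 3 (0.34 log units; beyond the scatter), though a smaller change, or none beyond the scatter, cannot be excluded. His estimate for compound 3 in this assay is 6500 nM, within a range of 1500 nM to 25000 nM.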

Compound 3, half-maximal inhibitory concentration: 1140 nM
For compound 3 the middle estimate is 5.7-fold (0.76 log units) above the measured one; measured number below the stated range.
By their numbers in this assay, from the lowest: compound 3; then compound 2; then compound 1.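

In this assay the place next to the ring nitrogen now orders three groups, with cyclopropyl giving the lowest number, methoxy the middle one and methyl the highest, and the new group extends the fall seen earlier (a 2.6-fold lower number from compound 2 to compound 3 (0.42 log units; beyond the scatter)). Cyclopropyl has no hydrogen-bond acceptor by the count, whereas methoxy has one, so among these compounds an acceptor at this place is not needed for the lower number. For the compounds shown here, the full span of the change (a 13-fold lower number from compound 1 to compound 3 (1.10 log units; beyond the scatter)) is the only large step and shows that this single place can carry much more of the difference in inhibition than the first step suggested, although no measurement here gives a reason for the order.

The compounds shown leave open whether the number keeps falling with a larger ring such as cyclobutyl, or whether an open chain such as isopropyl does as well, and how an amine or a chlorine would rank at the same place. They also leave open whether the same order holds once the trifluoromethyl group or the amide of the shared core is replaced.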